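The source may hold more compounds than are shown below. What is called first, only, known or untested is meant among the compounds shown, and "the series" means these compounds.

Compound 1, `COc1ccc(-n2c(SCC(=O)C3CC3)nnc2-c2cc(OC)c(OC)c(OC)c2)cc1`, compound 2, `CCOC(=O)CSc1nnc(-c2cc(OC)c(OC)c(OC)c2)n1-c1ccc(OC)cc1`, and compound 3, `COc1cc(-c2nnc(SCC(=O)C3CC3)n2-c2ccc(N(C)C)cc2)cc(OC)c1OC`, were tested in a functional assay on HepG2 cells (Homo sapiens) for inhibition, read by MTT assay, with a stated time of 48 h; a higher number here means a weaker inhibitor, a lower number a stronger inhibitor. In this assay compound 1 gives only a limit, > 60000 nM. Compound 2 likewise gives only a limit, > 60000 nM. Compound 3 too gives only a limit, > 60000 nM. The change from compound 1 to compound 2 is ethoxy in place of cyclopropyl on a carbonyl carbon, and its step is a step that the two limits leave unreadable from compound 1 to compound 2. The cores of compound 1 and compound 3 differ by dimethylamino in place of methoxy on an aromatic carbon, and that step is a step that the two limits leave unreadable from compound 1 to compound 3. Compound 4, `CCOC(=O)CSc1nnc(-c2cc(OC)c(OC)c(OC)c2)n1-c1ccc(N(C)C)cc1`, is not yet measured; it differs from compound 3 by ethoxy in place of cyclopropyl on a carbonyl carbon, the same change as from compound 1 to compound 2, at a place described in the same words. Going by the values given here, the expected step for compound 4 is a number no higher from compound 3 to compound 4 (the limit leaves the size open), an expectation that rests on (the limit of > 60000 nM in this assay, at which 3 of the 3 values shown sit), where every value so far sits. Compound 4 is expected to come out near 60000 nM, most likely again only as a limit, somewhere between 30000 nM and 200000 nM.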

Compound 4, half-maximal inhibitory concentration: > 60000 nM
Compound 4 ended at the assay's limit; the forecaster's own chance of this, stated with the estimate: 85%; the middle value lies on the limit itself.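

No size can be read for the step from compound 3 to compound 4 or from compound 2 to compound 4, because all of these values in this assay are limits and not numbers: the limit of > 60000 nM in this assay, at which 4 of the 4 values shown sit.

The compounds shown leave open how strongly compound 1, compound 2, compound 3 and compound 4 inhibit, and whether either exchange of groups changes that inhibition at all.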